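The source may report more compounds than this note shows. Statements on the series, on what has been measured and on what is new or still open speak of the compounds shown alone.

Measured so far in a functional assay on L1210 cells (Mus musculus) for inhibition (a lower number here means a stronger inhibitor, a higher number a weaker inhibitor), are these:

- compound 1 `O=C1/C(=C/c2cccc(Cl)c2)Cc2ccccc21` gives 41200 nM
- compound 2 `O=C1/C(=C/c2ccc(Cl)cc2)Cc2ccccc21` gives 54100 nM
- compound 3 `Cc1cccc(/C=C2\Cc3ccccc3C2=O)c1` gives 50400 nM

Compound 2 stands level with compound 1 and compound 3, since all three values lie within the scatter of each other. Unmeasured compound 4 `Cc1ccc(/C=C2\Cc3ccccc3C2=O)cc1` differs from compound 2 in one place. The change is methyl in place of chloro on an aromatic carbon and amounts to methyl in place of chloro on an aromatic carbon, para to a large group. Among the compounds with values here, one measured step bears on it, namely a 1.2-fold higher number from compound 1 to compound 3 (0.09 log units; within the scatter) and that is the same exchange, within the scatter. No step beyond the scatter is therefore expected in this assay for this change. The estimated step is a 1.0-fold lower number from compound 2 to compound 4 (0.02 log units; within the scatter) and stays inside the scatter. For compound 4 the estimate is 52000 nM with an expected range from 31000 nM to 85000 nM in this measurement.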

Compound 4, half-maximal inhibitory concentration: 59100 nM
Compound 4: the middle estimate sits 1.1-fold (0.06 log units) below what was measured; measured number inside the range.
By their numbers in this assay, from the lowest: compounds 1, 3, 2 and 4 (each within the scatter of the next).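

In this assay, methyl in place of chloro on an aromatic carbon, para to a large group, gives a 1.1-fold higher number from compound 2 to compound 4 (0.04 log units; within the scatter), so the exchange produces no step beyond the scatter at this position. The exchange now has two readings that agree, where compound 1 and compound 3 alone gave one: the same change on two cores in this assay, a 1.2-fold higher number (0.09 log units; within the scatter) from compound 1 to compound 3 and a 1.1-fold higher number (0.04 log units; within the scatter) from compound 2 to compound 4, 1.1-fold (0.05 log units) apart, within the scatter of two such steps

The substituents shown are limited to chloro and methyl, so the response of this position to other groups remains open. Whether an amine, a carboxylic acid or a longer chain here would move the number beyond the scatter is unresolved.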